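Phenyl for Ethoxycarbonyl on the Sulfamoyl Core

The source may hold more compounds than are shown below. What is called first, only, known or untested is meant among the compounds shown, and "the series" means these compounds.

Compound 1 `CCOC(=O)/C=N/c1cnc(Nc2ccc(N3CCN(C)CC3)cc2)nc1NC(C)C` gives 11500 nM in a functional assay on HeLa cells (Homo sapiens) for antiproliferative activity, read by MTT assay; on this read-out higher numbers stand for weaker inhibition and lower numbers for stronger inhibition. Compound 2 `CC(C)Nc1nc(Nc2ccc(N3CCN(C)CC3)cc2)ncc1/N=C/c1ccccc1` differs by phenyl in place of ethoxycarbonyl on a carbon with a double bond to nitrogen. For compound 2 this assay reports only a limit, > 100000 nM. That change gives an at least 8.6-fold higher number from compound 1 to compound 2 (0.93 log units; beyond the scatter). Compound 3 `CCOC(=O)/C=N/c1cnc(Nc2ccc(S(N)(=O)=O)cc2)nc1NC(C)C` has a different core, (sulfamoyl in place of 4-methylpiperazin-1-yl on an aromatic carbon), and in this assay compound 3 gives 83300 nM, which is a 7.2-fold higher number from compound 1 to compound 3 (0.86 log units; beyond the scatter). Compound 4 `CC(C)Nc1nc(Nc2ccc(S(N)(=O)=O)cc2)ncc1/N=C/c1ccccc1` is not yet measured; it differs from compound 3 by phenyl in place of ethoxycarbonyl on a carbon with a double bond to nitrogen, the same change at the same place as between compound 1 and compound 2. The expectation for compound 4 rests on that earlier step, an at least 8.6-fold higher number from compound 1 to compound 2 (0.93 log units; beyond the scatter), applied to the value of compound 3, 83300 nM. The step from compound 3 to compound 4 is therefore expected to be a 6.0-fold higher number from compound 3 to compound 4 (0.78 log units; beyond the scatter). Compound 4 is estimated to give about 500000 nM. Because one value already sits at the limit of > 100000 nM in this assay, at which 1 of the 3 values shown sits, compound 4 may well be reported only as a limit.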

Compound 4, half-maximal inhibitory concentration: > 100000 nM
Compound 4: only a limit was reported (the forecaster's own chance of this, stated with the estimate: 85%); the middle value lies beyond the limit too.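

In this assay, phenyl in place of ethoxycarbonyl gives an at least 1.2-fold higher number from compound 3 to compound 4 (0.07 log units; that floor lies within the scatter), so on the core of compound 3 the change is not shown to exceed the scatter, though the limit leaves room for a much larger step. Set beside the step on the core of compound 1, this leaves open whether the change carries over unchanged: the same change on two cores in this assay, an at least 8.6-fold higher number (0.93 log units; beyond the scatter) from compound 1 to compound 2 and an at least 1.2-fold higher number (0.07 log units; that floor lies within the scatter) from compound 3 to compound 4; the limit leaves it open whether they differ. The step between compound 2 and compound 4 cannot be read, and several of the compounds now sit at one limit: the limit of > 100000 nM in this assay, at which 2 of the 4 values shown sit.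

Only ethoxycarbonyl and phenyl are shown at this place. On these data alone, whether a carboxylic acid or an amide there would give readable values on both cores remains open.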